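This account rests on a few compounds, and the source may have more. Where it says the series, first, only, none or still open, it means among the compounds named here.

In an assay on isolated protein for inhibition of DNA topoisomerase 1 (Homo sapiens), with a stated time of 30 min, tested at 20 uM (a lower number here means a weaker effect, a higher number a stronger effect of the compound at the concentration tested), compound 1 `Oc1cccc(-c2cc(-c3ccccc3)cc(-c3ccccc3)n2)c1` gives 0%. Compound 2 `Oc1cccc(-c2cc(-c3ccccc3)nc(-c3ccccc3)c2)c1` carries the same groups arranged differently on the same core, and in this assay compound 2 gives 0%, level with compound 1 at the digits shown, so the two stand within the usual scatter of each other. Compound 3 `Oc1cccc(-c2cc(-c3ccccc3)nc(-c3ccsc3)c2)c1` differs from compound 2 in one place: thiophen-3-yl in place of phenyl on an aromatic carbon. For the measured compounds named here, no step between measured compounds is available to guide the expectation, and both measured values sit at no inhibition. The step is expected to stay within the scatter, a number 2 percentage points higher from compound 2 to compound 3 (within the scatter). Compound 3 is therefore estimated at 2%, in the range 0% to 15%.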

Compound 3, a percentage reported as inhibition, at one concentration (the size of the read-out at that concentration, not a potency): 3.2%
The estimate for compound 3 lay 1.2 percentage points below the measured number; measured number inside the range.
By their numbers in this assay, from the lowest: compounds 1, 2 and 3 (each within the scatter of the next).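

At this position, next to the ring nitrogen, thiophen-3-yl in place of phenyl gives a number 3.2 percentage points higher from compound 2 to compound 3 (within the scatter) in this assay, so the change does not separate the two compounds. A five-membered aromatic ring with a sulfur atom thus leaves compound 3 level with compound 2 in this read-out. No measurement shown here offers an explanation for this result. The compounds shown leave open whether an amine or a carboxylic acid at this position would move the read-out beyond the scatter. They also leave open whether replacing the 3-hydroxyphenyl group would do so.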